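Replacing 2-hydroxyphenyl with 4-chlorophenyl in compound 3

The compounds below may be only part of what the source reports. "The series", "measured", "known", "first", "only" and "open" are said of these compounds alone.

Compound 1 `CC1(C)[C@H]2CC[C@]1(C)N(Cc1cn(-c3ccccc3Br)nn1)C(=O)C2` gives 280 nM
Compound 2 `CC1(C)[C@H]2CC[C@]1(C)N(Cc1cn(-c3ccc(O)cc3)nn1)C(=O)C2` gives 100 nM
Compound 3 `CC1(C)[C@H]2CC[C@]1(C)N(Cc1cn(-c3ccccc3O)nn1)C(=O)C2` gives 230 nM

These values come from a functional assay on PANC-1 cells (Homo sapiens) for inhibition, read by MTT assay, with a stated time of 24 h; on this read-out higher numbers stand for weaker inhibition and lower numbers for stronger inhibition. Compound 3 cannot be told apart from compound 1, and its number is higher than that of compound 2. Compound 4 `CC1(C)[C@H]2CC[C@]1(C)N(Cc1cn(-c3ccc(Cl)cc3)nn1)C(=O)C2` comes next, with this change: 4-chlorophenyl in place of 2-hydroxyphenyl on an aromatic nitrogen. Among the measured compounds shown here, two measured steps bear on it. Placing 2-hydroxyphenyl where 4-hydroxyphenyl stood gave a 2.3-fold higher number from compound 2 to compound 3 (0.36 log units; beyond the scatter), a modest step, while hydroxy in place of bromo gave a 1.2-fold lower number from compound 1 to compound 3 (0.09 log units; within the scatter). For the measured compounds named here, no chlorinated compound has been measured, so the 4-hydroxyphenyl of compound 2 is only a loose guide. The expected result is a 1.5-fold lower number from compound 3 to compound 4 (0.19 log units; within the scatter), a lowering too small to clear the scatter. For compound 4 the estimated value is 150 nM, with an expected range from 60 nM to 400 nM.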

Compound 4, half-maximal inhibitory concentration: 440 nM
Beside the measured number, compound 4's estimate is 2.9-fold (0.47 log units) below it; measured number above the stated range.
By their numbers in this assay, from the lowest: compound 2; then compounds 3, 1 and 4 (each within the scatter of the next).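

Chloro in place of hydroxy on the same aromatic carbon gives a clear change (a 4.4-fold higher number from compound 2 to compound 4 (0.64 log units; beyond the scatter)), so the 4-hydroxyphenyl of compound 2 keeps its lead over 4-chlorophenyl. By contrast, 4-chlorophenyl cannot be told apart from 2-hydroxyphenyl (a 1.9-fold higher number from compound 3 to compound 4 (0.28 log units; within the scatter)) or from 2-bromophenyl (a 1.6-fold higher number from compound 1 to compound 4 (0.20 log units; within the scatter)). Nothing available here explains these differences.

Going by these compounds, it remains open whether the hydroxy itself is what compound 2 needs. An amine or a carboxylic acid in its place could match the number of compound 2 or move away from it.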